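Changing the Oxygen Substituent of Compound 2

The compounds below may be only part of what the source reports. "The series", "measured", "known", "first", "only" and "open" are said of these compounds alone.

Two close relatives have been measured so far in a functional assay on MCF7 cells (Homo sapiens) for inhibition, read by radiometric assay and XTT assay; on this read-out lower numbers stand for stronger inhibition and higher numbers for weaker inhibition. Compound 1 (`C=CCOC1=CC(=O)S[C@]1(C)CCCCCC`) gives 9 ug/mL, and compound 2 (`C=CCOC1=CC(=O)S[C@]1(C)CCCCCCCC`) gives 14.5 ug/mL. Compound 2 therefore stands level with compound 1 within the usual scatter, and nothing yet separates the two.

The next structure, compound 3 (`CCCCCCCC[C@@]1(C)SC(=O)C=C1OC(=O)CC`), keeps the saturated chain of compound 2 but carries propanoyl in place of allyl on an oxygen on an unsaturated carbon. In counted terms the difference is propanoyl in place of allyl on an oxygen on an unsaturated carbon.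

Going by the values given here, only one measured step exists, a 1.6-fold higher number from compound 1 to compound 2 (0.21 log units; within the scatter). It lies in the saturated chain and not at this oxygen, so it shows only that this assay changed little there. Among the compounds with values here, no measured compound tests a change at the oxygen, which leaves the direction open and calls for a wide range.

The expected result is a 1.1-fold lower number from compound 2 to compound 3 (0.05 log units; within the scatter), with no firm step beyond the scatter anticipated. For compound 3 the estimate is 13 ug/mL, with an expected range from 5 ug/mL to 32 ug/mL.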

Compound 3, half-maximal inhibitory concentration: 26.8 ug/mL
The estimate for compound 3 lay 2.1-fold (0.31 log units) below the measured number; low and high end bracket the measured number.
By their numbers in this assay, from the lowest: compounds 1, 2 and 3 (each within the scatter of the next, the first and the last beyond it).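

The first change tested at this oxygen, allyloxy to propanoyloxy, gives a 1.8-fold higher number from compound 2 to compound 3 (0.27 log units; within the scatter) in this assay and so leaves compound 2 and compound 3 level with each other. The swap is not a trivial one on paper: propanoyl brings one more heavy atom than allyl, an oxygen that counts as a hydrogen-bond acceptor, yet this added atom produces no step beyond the usual scatter of repeated measurements. No supporting evidence is available to explain how either group acts at this position, so the result stands as a plain observation about these two compounds.

On these data alone, what stays open is whether any group on this oxygen can move the number beyond the scatter, for instance a benzoyl group, a longer acyl chain such as octanoyl, or an acyl group carrying an amine or a carboxylic acid. It is also unknown whether propanoyl would behave in the same way on the shorter saturated chain of compound 1, since a single pair cannot show whether the two positions act independently.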